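This account rests on a few compounds, and the source may have more. Where it says the series, first, only, none or still open, it means among the compounds named here.

For the measured compounds named here, the two compounds measured so far share one core and differ only in the group on the amide-type nitrogen. Compound 1 `N#Cc1cc(NC(=O)CN2C(=O)/C(=C/c3ccc(-c4ccc(Cl)cc4)o3)SC2=S)ccc1C(F)(F)F` carries a 3-cyano-4-(trifluoromethyl)phenyl there. In a functional assay on K562 cells (Homo sapiens) for cytotoxicity, read by MTT assay, with a stated time of 72 h (a higher number here means a weaker inhibitor, a lower number a stronger inhibitor), compound 1 reaches only the limit of the assay, > 250000 nM, which is a limit and not a number. Compound 2 `CCCCCCNC(=O)CN1C(=O)/C(=C/c2ccc(-c3ccc(Cl)cc3)o2)SC1=S` carries a hexyl in its place, and in this assay compound 2 gives 50000 nM. Going by the values given here, of the two values shown this is the only number, the other being (the limit of > 250000 nM in this assay, at which 1 of the 2 values shown sits). Among the compounds with values here, the single measured step is an at least 5.0-fold lower number from compound 1 to compound 2 (0.69 log units; beyond the scatter), where an aromatic ring sitting directly on the nitrogen gave way to a chain.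

Compound 3 `Cc1cccc(CNC(=O)CN2C(=O)/C(=C/c3ccc(-c4ccc(Cl)cc4)o3)SC2=S)c1` differs from compound 2 in one place: 3-methylphenyl in place of pentyl on a saturated chain carbon bound to an amide-type nitrogen. Within the data shown here, compound 3 keeps a saturated chain carbon on the nitrogen and places an aromatic ring one bond further out, a change that no measured pair shows. Compound 3 is therefore expected to stay close to compound 2, with the step of a 1.3-fold lower number from compound 2 to compound 3 (0.10 log units; within the scatter) expected to remain within the scatter. The estimate for compound 3 in this assay is 40000 nM, between 10000 nM and 160000 nM.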

Compound 3, half-maximal inhibitory concentration: 48000 nM
Compound 3: the middle estimate sits 1.2-fold (0.08 log units) below what was measured, and the stated range covers the measured number.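

In this assay, replacing the hexyl of compound 2 with the 3-methylbenzyl of compound 3 gives a 1.0-fold lower number from compound 2 to compound 3 (0.02 log units; within the scatter), so at this position the chain and the ring-bearing group cannot be told apart. The earlier pair could be read as a penalty for any aromatic ring on this side of the molecule, but compound 3 carries one on a saturated chain carbon bound to the amide-type nitrogen and still gives an at least 5.2-fold lower number from compound 1 to compound 3 (0.71 log units; beyond the scatter), which shows that an aromatic ring alone does not produce the weak result of compound 1. Compound 1 stands at a limit and not at a number, so this step gives only a minimum size: the limit of > 250000 nM in this assay, at which 1 of the 3 values shown sits.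

Compound 1 differs from compound 3 both in how its ring is attached and in its nitrile and trifluoromethyl groups, so the compounds shown do not say which of these matters. From the compounds shown here alone, whether an amine, a carboxylic acid or a chain longer than hexyl on this nitrogen would shift the number away from that of compound 2 also stays open.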